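The source may hold more compounds than are shown below. What is called first, only, known or untested is meant among the compounds shown, and "the series" means these compounds.

Compound 1 `Cc1ccc(-c2ccnc(Nc3ccc4c(c3)c(/C=C3/C(=O)Nc5ccccc53)cn4C)n2)cc1`; in a functional assay on MCF7 cells (Homo sapiens) for cytotoxicity, read by MTT assay, with a stated time of 48 h (a higher number here means a weaker inhibitor, a lower number a stronger inhibitor), compound 1 gives > 100000 nM, which is a limit of the assay and not a number. Compound 2 `Cn1cc(/C=C2/C(=O)Nc3ccccc32)c2cc(Nc3nccc(-c4ccc(O)cc4)n3)ccc21`; in this assay compound 2 gives 39600 nM. Compound 3 `Cn1cc(/C=C2/C(=O)Nc3ccccc32)c2cc(Nc3nccc(-c4ccc(C(F)(F)F)cc4)n3)ccc21`; in this assay compound 3 gives 65200 nM.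

Compound 1 stands at the limit of > 100000 nM in this assay, at which 1 of the 3 values shown sits, so its position is known only as a limit. Exchanges on the same aromatic carbon gave an at least 2.5-fold lower number from compound 1 to compound 2 (0.40 log units; beyond the scatter) and an at least 1.5-fold lower number from compound 1 to compound 3 (0.18 log units; that floor lies within the scatter). Compound 4 `Cn1cc(/C=C2/C(=O)Nc3ccccc32)c2cc(Nc3nccc(-c4cccs4)n3)ccc21` differs from compound 1 by thiophen-2-yl in place of 4-methylphenyl on an aromatic carbon. Both measured steps bear on this change, and both left weak inhibitors. Compound 4 is therefore expected to remain weak, with a step of an at least 1.2-fold lower number from compound 1 to compound 4 (0.09 log units; that floor lies within the scatter) expected. The estimate for compound 4 in this assay is 80000 nM, expected between 30000 nM and 200000 nM.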

Compound 4, half-maximal inhibitory concentration: 30800 nM
The estimate for compound 4 lay 2.6-fold (0.41 log units) above the measured number, within the range that was stated.
By their numbers in this assay, from the lowest: compounds 4, 2 and 3 (each within the scatter of the next, the first and the last beyond it). At a limit, above all of these: compound 1.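

In this assay, this position takes a five-membered aromatic ring as well as a substituted phenyl: thiophen-2-yl gives an at least 3.2-fold lower number from compound 1 to compound 4 (0.51 log units; beyond the scatter) and a 2.1-fold lower number from compound 3 to compound 4 (0.33 log units; beyond the scatter). Against 4-hydroxyphenyl it gives a 1.3-fold lower number from compound 2 to compound 4 (0.11 log units; within the scatter), so a hydroxy group is not required to reach this level. In compound 1, > 100000 nM is a limit of the assay, so the step from it gives only a floor.

The compounds shown do not separate the effect of ring size from that of the sulfur atom. They also leave open whether furan-2-yl or a phenyl bearing an amine or a carboxylic acid would lower the number further.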